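Thiophene isomer swap at the amide of the shared core

The compounds below may be only part of what the source reports. "The series", "measured", "known", "first", "only" and "open" are said of these compounds alone.

Measured so far in a functional assay on MKN-7 cells (Homo sapiens) for inhibition, read by colorimetric assay and sulforhodamine B assay, with a stated time of 48 h; a lower number here means a stronger inhibitor of growth, a higher number a weaker inhibitor of growth:
compound 1 `CCCCCCCCCCCC[C@@H](O)[C@H]1CC[C@H]([C@H](O)CCCCCCCCCCNC(=O)c2cncs2)O1`: 617 nM
compound 2 `CCCCCCCCCCCC[C@@H](O)[C@H]1CC[C@H]([C@H](O)CCCCCCCCCCNC(=O)c2ccsc2)O1`: 170 nM
compound 3 `CCCCCCCCCCCC[C@@H](O)[C@H]1CC[C@H]([C@H](O)CCCCCCCCCCNC(=O)c2ccnn2C)O1`: 10 nM

Compound 2 holds the second highest number of the three. Its nearest neighbour is compound 1, a 3.6-fold lower number from compound 1 to compound 2 (0.56 log units; beyond the scatter); its furthest is compound 3, a 17-fold lower number from compound 2 to compound 3 (1.23 log units; beyond the scatter). The remaining pair shows a 62-fold lower number from compound 1 to compound 3 (1.79 log units; beyond the scatter), so among these three the ring on the carbonyl carbon matters a great deal.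

Compound 4 `CCCCCCCCCCCC[C@@H](O)[C@H]1CC[C@H]([C@H](O)CCCCCCCCCCNC(=O)c2cccs2)O1` differs from compound 2 in one place: thiophen-2-yl in place of thiophen-3-yl on a carbonyl carbon.

Going by the values given here, no measured step swaps one thiophenyl for another; the three measured steps all exchange rings of different heteroatom content, and each lay beyond the scatter. They show only that this position is sensitive, not in which direction a move within the same ring type would go. Without a closer precedent, the number for compound 4 is expected to stay near that of compound 2, with no change at the digits printed from compound 2 to compound 4 (within the scatter) judged to be within the scatter, though the spread allowed is wide. Compound 4 is therefore estimated at 170 nM in this assay, between 55 nM and 520 nM.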

Compound 4, concentration for 50% growth inhibition: 269 nM
Beside the measured number, compound 4's estimate is 1.6-fold (0.20 log units) below it; the measured number falls inside the stated range.
By their numbers in this assay, from the lowest: compound 3; then compounds 2 and 4 (each within the scatter of the next); then compound 1.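

In this assay, going by these compounds alone, the first same-ring comparison at this position shows that moving the attachment from thiophen-3-yl to thiophen-2-yl on the carbonyl carbon gives no readable difference: a 1.6-fold higher number from compound 2 to compound 4 (0.20 log units; within the scatter). The two thiophenyl isomers therefore stand together, and the steps from the other rings still hold with thiophen-2-yl as the partner: a 27-fold higher number from compound 3 to compound 4 (1.43 log units; beyond the scatter) for the exchange of 1-methyl-1H-pyrazol-5-yl, and a 2.3-fold lower number from compound 1 to compound 4 (0.36 log units; beyond the scatter) for the exchange of 1,3-thiazol-5-yl. Among these four compounds, the choice of ring thus separates the numbers far more than the attachment point of the thiophene does, though no measurement of any property of these groups is available to account for that.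

As far as these compounds go, whether attachment point is equally silent for the other rings stays open, since the pyrazole and thiazole each appear here in one form only. From the compounds shown here alone, it is also open whether a plain phenyl ring on the carbonyl carbon would fall with the thiophenyl pair or nearer compound 3, and whether compound 3 keeps its number with hydrogen in place of the methyl on its pyrazole ring.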